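Pentafluorophenylsulfonyl Variant of a Quinolone: Expected Potency

The source may report more compounds than this note shows. Statements on the series, on what has been measured and on what is new or still open speak of the compounds shown alone.

Measured compounds:
compound 1, `C=CCNC(=O)n1c(-c2ccc(OC)cc2)cc(=O)c2c(OC)cc(OC)cc21`, 12000 nM
compound 2, `COc1ccc(-c2cc(=O)c3c(OC)cc(OC)cc3n2S(=O)(=O)c2ccc(C)c([N+](=O)[O-])c2)cc1`, "not determined" (no result reported)

In a functional assay on SEM cells (Homo sapiens) for antiproliferative activity, with a stated time of 72 h (a lower number here means that less compound is needed, a higher number that more compound is needed for the effect), compound 1 gives 12000 nM. Compound 2 has no result in this assay; it stands as "not determined" (no result reported). Among the measured compounds shown here, no step between measured compounds is available, since compounds 1 and 2 differ in more than one place, and compound 2 offers no number to step from.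

Compound 3, `COc1ccc(-c2cc(=O)c3c(OC)cc(OC)cc3n2S(=O)(=O)c2c(F)c(F)c(F)c(F)c2F)cc1`, differs from compound 2 by 2,3,4,5,6-pentafluorophenyl in place of 4-methyl-3-nitrophenyl on a sulfonyl sulfur. For the measured compounds named here, without a value for compound 2, the size and direction of this change in this assay cannot be read from a measured pair; the only anchor is compound 1, which itself sits at the weak end with 12000 nM. The sulfonyl compounds share the core of compound 1, so a similarly weak result is the most defensible expectation, with a wide margin in either direction. Compound 3 is therefore estimated at 9000 nM in this assay, with a range from 1500 nM to 40000 nM.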

Compound 3, half-maximal effective concentration: 3900 nM
For compound 3 the middle estimate is 2.3-fold (0.36 log units) above the measured one, within the range that was stated.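

Among the compounds shown here, compound 3 yields no new step: compound 2 offers no number in this assay, and compound 1 differs from compound 3 in more than one place. The compounds shown leave open what 2,3,4,5,6-pentafluorophenyl in place of 4-methyl-3-nitrophenyl does to the result. Nothing shown here bears on the value of compound 3.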